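A few compounds are considered here, and "the series" means these few. Any claim that something is new, unique, unknown or untested is made for them only; others in the source may bear on it.

Measured compounds:
compound 1, `O=C(CSc1nc(Nc2ccccc2)c2ccccc2n1)Nc1ccc(Br)cc1`, 10600 nM
compound 2, `O=C(CSc1nc(Nc2ccccc2)c2ccccc2n1)Nc1ccc([N+](=O)[O-])cc1`, 13000 nM
compound 3, `C=CC(=O)Nc1cccc(NC(=O)CSc2nc(Nc3cccc(Br)c3)c3ccccc3n2)c1`, 12100 nM

These three compounds were tested in a functional assay on NCI-H1975 cells (Homo sapiens) for inhibition, read by MTT assay, with a stated time of 72 h; a higher number here means a weaker inhibitor, a lower number a stronger inhibitor. Compound 1 gives 10600 nM there, compound 2 gives 13000 nM, and compound 3 gives 12100 nM. All three values sit within the usual scatter of one another, so no order among them can be read from these numbers.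

Compound 1 and compound 2 differ in one place, (nitro in place of bromo on an aromatic carbon), and that change made a step of a 1.2-fold higher number from compound 1 to compound 2 (0.09 log units; within the scatter) in this assay.

Compound 4, `C=CC(=O)Nc1cccc(NC(=O)CSc2nc(Nc3cccc([N+](=O)[O-])c3)c3ccccc3n2)c1`, has not yet been measured. It differs from compound 3 by nitro in place of bromo on an aromatic carbon. Compound 3 and compound 1 share the same kind of change to reach their partners, but the difference between the two cores is not broken down here. The surroundings of the change also differ: in the pair from compound 1 to compound 2 the exchanged group sits para to a large group, whereas in the pair from compound 3 to compound 4 it sits meta to a large group, so this is the same kind of change rather than the same change.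

Within the data shown here, the expectation for compound 4 rests on the one measured instance, and compound 4 is expected to show a step of a 1.2-fold higher number from compound 3 to compound 4 (0.06 log units; within the scatter) from compound 3 because a 1.2-fold higher number from compound 1 to compound 2 (0.09 log units; within the scatter) was within the scatter. Compound 4 is therefore estimated at 14000 nM in this assay, with a likely range from 6000 nM to 32000 nM.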

Compound 4, half-maximal inhibitory concentration: 22600 nM
Compound 4: middle estimate off by 1.6-fold (0.21 log units), on the low side, within the range that was stated.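

In this assay, nitro in place of bromo on the core of compound 3 gave a step of a 1.9-fold higher number from compound 3 to compound 4 (0.27 log units; within the scatter), so this exchange cannot be told apart from the spread of repeated measurements on this core. The step on this core and the earlier one on the core of compound 1 do not differ by more than such steps normally do: the same change on two cores in this assay, a 1.2-fold higher number (0.09 log units; within the scatter) from compound 1 to compound 2 and a 1.9-fold higher number (0.27 log units; within the scatter) from compound 3 to compound 4, 1.5-fold (0.18 log units) apart, within the scatter of two such steps. This shows that, across these two pairs, the exchange gave no readable effect on either core and no readable difference between them, but it does not show that the effect of the change carries over, since there is no step beyond the scatter to carry, and the exchanged group sits in different surroundings in the two pairs.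

The compounds shown leave open whether any group at this place would separate itself from bromo and nitro in this assay, for instance an amine, a carboxylic acid or a methoxy group. They also leave open how the two cores compare with each other, as compound 1 and compound 3 differ in more than one place and every value here lies close to the others.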